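Chloro on the phenyl of compound 2

A few compounds are considered here, and "the series" means these few. Any claim that something is new, unique, unknown or untested is made for them only; others in the source may bear on it.

Measured so far in a functional assay on MCF7 cells (Homo sapiens) for inhibition, read by MTT assay, with a stated time of 48 h; a higher number here means a weaker inhibitor, a lower number a stronger inhibitor
- compound 1 `COc1ccc(-c2nc3c(c(-c4ccccc4)nn3-c3ccccc3)c(-c3ccc(N4CCCCC4)cc3)c2C#N)cc1` gives 2760 nM
- compound 2 `N#Cc1c(-c2ccccc2)nc2c(c(-c3ccccc3)nn2-c2ccccc2)c1-c1ccc(N2CCCCC2)cc1` gives 27000 nM
- compound 3 `c1ccc(-c2ccnc3c2c(-c2ccccc2)nn3-c2ccccc2)cc1` gives 28200 nM

Compound 2 at 27000 nM sits level with compound 3 at 28200 nM within the scatter, and well away from compound 1. The next entry, compound 4 `N#Cc1c(-c2ccc(Cl)cc2)nc2c(c(-c3ccccc3)nn2-c2ccccc2)c1-c1ccc(N2CCCCC2)cc1`, differs from compound 2 by chloro in place of hydrogen on an aromatic carbon, or phenyl to 4-chlorophenyl when cut one bond further out.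

Among the measured compounds shown here, only one measured step bears on this change: a 9.8-fold higher number from compound 1 to compound 2 (0.99 log units; beyond the scatter), and it concerns the same phenyl, which carries methoxy in compound 1 and nothing in compound 2. That step shows that a group on this phenyl can shift the number in this assay beyond the scatter, with the substituted compound holding the lower number. For the measured compounds named here, no chloro compound has been measured yet, so only part of that step is carried over. The expected change is a 2.3-fold lower number from compound 2 to compound 4 (0.35 log units; beyond the scatter), estimated to run toward a lower number, smaller than the methoxy step, with a range that still includes no change. In this assay compound 4 is estimated at 12000 nM with an expected range from 4000 nM to 32000 nM on the strength of that single step.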

Compound 4, half-maximal inhibitory concentration: 10600 nM
The estimate for compound 4 lay 1.1-fold (0.05 log units) above the measured number, within the range that was stated.
By their numbers in this assay, from the lowest: compound 1; then compound 4; then compounds 2 and 3 (each within the scatter of the next).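

In this assay, the phenyl of compound 2 now has a second substituent with a step beyond the scatter (a 2.5-fold lower number from compound 2 to compound 4 (0.41 log units; beyond the scatter)), so the lower number seen with methoxy is not confined to that one group. Chloro and methoxy are also not interchangeable at this place on the ring, since the direct comparison between them, also beyond the scatter, favours methoxy (a 3.8-fold higher number from compound 1 to compound 4 (0.58 log units; beyond the scatter)). Across the three compounds that differ only here, unsubstituted compound 2 has the highest number and both substituted compounds lie below it, while methoxy on compound 1 remains the lowest; no measurement offered here explains this order.

On these data alone, whether the trend extends to an amine, a carboxylic acid or a longer alkoxy chain on this phenyl remains open, as two substituents cannot define how the number depends on the group. As far as these compounds go, it is equally open whether chloro would produce a similar step on the other phenyl groups of the shared core, or whether replacing the piperidine would change what this position contributes.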